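Amino-to-glycinate change on two vinyl sulfone cores

The compounds below may be only part of what the source reports. "The series", "measured", "known", "first", "only" and "open" are said of these compounds alone.

Measured so far:
compound 1 `COc1cc(OC)c(/C=C/S(=O)(=O)Cc2ccc(OC)c(N)c2)c(OC)c1`: 4 nM
compound 3 `COC(=O)CNc1cc(CS(=O)(=O)/C=C/c2c(OC)cc(OC)cc2OC)ccc1OC`: 100 nM
compound 2 `COc1ccc(CS(=O)(=O)/C=C/c2cc(OC)c(OC)c(OC)c2)cc1N`: 3000 nM

In a functional assay on DU-145 cells (Homo sapiens) for cytotoxicity, read by trypan blue exclusion, with a stated time of 96 h (on this read-out lower numbers stand for stronger inhibition and higher numbers for weaker inhibition), compound 1 gives 4 nM, the lowest number of the three. The change (methoxycarbonyl)methyl in place of hydrogen on a nitrogen on an aromatic ring gives a step of a 25-fold higher number from compound 1 to compound 3 (1.40 log units; beyond the scatter). Compound 2 shares its atoms with compound 1 but joined differently; the difference between the two cores is not broken down here. In this assay compound 2 gives 3000 nM, the highest number of the three.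

Compound 4 `COC(=O)CNc1cc(CS(=O)(=O)/C=C/c2cc(OC)c(OC)c(OC)c2)ccc1OC` carries the same change on the core of compound 2: (methoxycarbonyl)methyl in place of hydrogen on a nitrogen on an aromatic ring. The place is the same in both pairs. Since the step from compound 1 to compound 3 was large, the step from compound 2 to compound 4 is expected to be of a similar kind, estimated at a 10-fold higher number from compound 2 to compound 4 (1.00 log units; beyond the scatter), resting on a 25-fold higher number from compound 1 to compound 3 (1.40 log units; beyond the scatter) alone and so uncertain. Compound 4 is therefore estimated at 30000 nM, between 5000 nM and 150000 nM.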

Compound 4, half-maximal inhibitory concentration: 75000 nM
Compound 4: the middle estimate sits 2.5-fold (0.40 log units) below what was measured; the range from low to high includes it.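

Carried to the other core, the change gives a 25-fold higher number from compound 2 to compound 4 (1.40 log units; beyond the scatter) and in this assay the two pairs agree: the same change on two cores in this assay, a 25-fold higher number (1.40 log units; beyond the scatter) from compound 1 to compound 3 and a 25-fold higher number (1.40 log units; beyond the scatter) from compound 2 to compound 4, 1.0-fold (0.00 log units) apart, within the scatter of two such steps

These two pairs show that the size of the step carried over between these two cores. They do not show that it would hold on any further core, and they do not explain why the number rises on either one.

The compounds shown leave open which part of the (methoxycarbonyl)methyl group goes with the step, the methyl ester or the chain that carries it. A carboxylic acid in place of the ester, or a longer chain on the same nitrogen, would separate the two on both cores.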